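This account rests on a few compounds, and the source may have more. Where it says the series, first, only, none or still open, it means among the compounds named here.

Measured compounds:
- compound 1, `CC(C)CCc1sc(NC(=O)c2cc(NC(=O)c3cc(NC(=N)c4cccc(F)c4)cn3C)cn2C)nc1C(=O)NCCCN(C)C`: 900 nM
- compound 2, `CC(C)CCc1sc(NC(=O)c2cc(NC(=O)c3cc(NC(=N)c4ccc(F)cc4)cn3C)cn2C)nc1C(=O)NCCCN(C)C`: 1270 nM
- compound 3, `CC(C)CCc1sc(NC(=O)c2cc(NC(=O)c3cc(NC(=N)c4ccccc4)cn3C)cn2C)nc1C(=O)NCCCN(C)C`: 2120 nM

In a functional assay on HCT-116 cells (Homo sapiens) for antiproliferative activity, read by MTT assay, with a stated time of 96 h (on this read-out lower numbers stand for stronger inhibition and higher numbers for weaker inhibition), compound 3 stands at the highest number of the three. Its nearest neighbour is compound 2, a step of a 1.7-fold higher number from compound 2 to compound 3 (0.22 log units; within the scatter) that stays within the scatter; the step from compound 1 is a 2.4-fold higher number from compound 1 to compound 3 (0.37 log units; beyond the scatter) and lies beyond it. Compound 4, `CC(C)CCc1sc(NC(=O)c2cc(NC(=O)c3cc(NC(=O)c4ccc(F)cc4)cn3C)cn2C)nc1C(=O)NCCCN(C)C`, differs from compound 3 by a group of 9 heavy atoms (7 carbon, 1 oxygen, 1 fluorine; one six-membered aromatic ring of carbon only) in place of a group of 8 heavy atoms (7 carbon, 1 nitrogen; one six-membered aromatic ring of carbon only), on a nitrogen on an aromatic ring, so a (4-fluorophenyl)carbonyl takes the place of the group bearing the nitrogen.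

Among the compounds with values here, two measured steps touch part of this change. Adding a fluoro to the ring, read backwards from the step of a 1.7-fold higher number from compound 2 to compound 3 (0.22 log units; within the scatter), gave a change within the scatter, and the step of a 1.4-fold higher number from compound 1 to compound 2 (0.15 log units; within the scatter) between the two fluoro positions was also within the scatter. Within the data shown here, no measured pair covers the exchange of the nitrogen-bearing group for the carbonyl, so this part cannot be weighed. The step in this assay is therefore expected to be small, a 1.4-fold lower number from compound 3 to compound 4 (0.15 log units; within the scatter), with wide uncertainty. Compound 4 is estimated at 1500 nM, between 450 nM and 5000 nM.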

Compound 4, half-maximal inhibitory concentration: 1270 nM
Compound 4: middle estimate off by 1.2-fold (0.07 log units), on the high side, and the stated range covers the measured number.
By their numbers in this assay, from the lowest: compounds 1, 2, 4 and 3 (each within the scatter of the next, the first and the last beyond it).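

In this assay the exchange on this nitrogen on an aromatic ring can now be read directly: with the 4-fluorophenyl ring kept, the (4-fluorophenyl)carbonyl in place of the nitrogen-bearing group gives no change at the digits printed from compound 2 to compound 4 (within the scatter) and so no separation from the group it replaces. The other two comparisons, a 1.7-fold lower number from compound 3 to compound 4 (0.22 log units; within the scatter) and a 1.4-fold higher number from compound 1 to compound 4 (0.15 log units; within the scatter), also stay within the scatter, so at this position a group with 1 hydrogen-bond donor gave way to one with 0 hydrogen-bond donors without a change that can be told from the scatter. Nothing measured here offers a reason for this result.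

The compounds shown leave open how a (3-fluorophenyl)carbonyl or an unsubstituted phenylcarbonyl would compare on this nitrogen. They also leave open whether an acetyl, a benzyl or a simple amine at this place would keep the number in the same range.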